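The source may report more compounds than this note shows. Statements on the series, on what has been measured and on what is new or still open speak of the compounds shown alone.

The set rests on one shared core, a sulfonamide joined through a hydroxylated chain to a basic amine, and the compounds differ only in that amine. Compound 1 `CCC1CCC(C)N(C[C@@H](O)CNS(=O)(=O)c2cccc3ccccc23)C1` gives 1000 nM in an assay on HEK293 cells for inhibition of sodium- and chloride-dependent glycine transporter 1 (Homo sapiens); a higher number here means a weaker inhibitor, a lower number a stronger inhibitor. Within the data shown here, compound 2 `O=S(=O)(NC[C@H](O)CN1CCCC1)c1cccc2ccccc12` gives 3160 nM in this assay, the higher of the two single numbers so far; its nearest neighbour is compound 1, and the step of a 3.2-fold higher number from compound 1 to compound 2 (0.50 log units; beyond the scatter) lies beyond the scatter. Compound 3 `CC(C)CC1CCCN1C[C@@H](O)CNS(=O)(=O)c1cccc2ccccc12` has been measured twice, giving 2510 nM; 6310 nM (2 entries), so it carries no single number, and the several entries of compound 3 in this assay, 2510 nM; 6310 nM (2 entries) shows how widely repeat measurements of one compound can spread in this assay.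

Compound 4 `CCCN(C[C@@H](O)CNS(=O)(=O)c1cccc2ccccc12)C(C)CC` is not yet measured. It differs from compound 2 in one place: propyl(sec-butyl)amino in place of pyrrolidin-1-yl on a saturated chain carbon, two bonds along the chain from an oxygen on a saturated carbon. Among the measured compounds shown here, the only measured step that bears on this change is a 3.2-fold higher number from compound 1 to compound 2 (0.50 log units; beyond the scatter), in which a larger, more substituted cyclic amine stood in place of pyrrolidin-1-yl and the number was modestly lower. The amine entering compound 4 is again larger than pyrrolidin-1-yl, though open-chain rather than cyclic, so a modest downward step is expected, a 2.1-fold lower number from compound 2 to compound 4 (0.32 log units; beyond the scatter). Compound 4 is therefore estimated at 1500 nM, with a range from 500 nM to 5000 nM.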

Compound 4, half-maximal inhibitory concentration: 1260 nM
Compound 4: middle estimate off by 1.2-fold (0.08 log units), on the high side; the measured number falls inside the stated range.
By their numbers in this assay, from the lowest: compounds 1 and 4 (each within the scatter of the next); then compound 2.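

In this assay, replacing pyrrolidin-1-yl with propyl(sec-butyl)amino on a saturated chain carbon, two bonds along the chain from an oxygen on a saturated carbon, gives a 2.5-fold lower number from compound 2 to compound 4 (0.40 log units; beyond the scatter), so a lower number at this position does not require a ring in the entering amine, which compound 1 alone could not show. The comparison of the open-chain amine with the cyclic 5-ethyl-2-methylpiperidin-1-yl gives a 1.3-fold higher number from compound 1 to compound 4 (0.10 log units; within the scatter), so these two amines cannot be separated in this assay despite their different shapes. Compound 3 stays outside this reading, since it carries no single number and its repeat measurements spread about as widely as these steps: the several entries of compound 3 in this assay, 2510 nM; 6310 nM (2 entries)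

The compounds shown leave open whether an unsubstituted piperidine, a morpholine or a small open-chain amine such as diethylamino would also give a lower number than pyrrolidin-1-yl. They also leave open whether the sec-butyl or the propyl group of compound 4 accounts for its step, which a dipropylamino or a propylamino group at the same place could begin to separate.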